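The source may report more compounds than this note shows. Statements on the series, on what has been measured and on what is new or still open speak of the compounds shown alone.

Measured so far in a functional assay on HBL-100 cells (Homo sapiens) for antiproliferative activity, read by sulforhodamine B assay, with a stated time of 48 h; on this read-out lower numbers stand for stronger inhibition of growth and higher numbers for weaker inhibition of growth:
compound 1 `COC(=O)C#CC(O/C=C/C(=O)OC)C1CCCCC1`: 2500 nM
compound 2 `CCCC(C#CC(=O)OC)O/C=C/C(=O)OC`: 270 nM
compound 3 `COC(=O)C#CC(CC(C)C)O/C=C/C(=O)OC`: 330 nM

These three compounds share a core and differ in one group. Compound 3 gives 330 nM, which puts it close to compound 2 and far from compound 1. This shows in a 1.2-fold higher number from compound 2 to compound 3 (0.09 log units; within the scatter) and in a 7.6-fold lower number from compound 1 to compound 3 (0.88 log units; beyond the scatter).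

The next compound is compound 4 `COC(=O)C#CC(O/C=C/C(=O)OC)C1CC1`, which has cyclopropyl in place of isobutyl on a saturated chain carbon bound to an oxygen on an unsaturated carbon and a triple-bonded carbon.

Two kinds of measured step bear on this change. Swapping one open chain for the other made little difference, as a 1.2-fold higher number from compound 2 to compound 3 (0.09 log units; within the scatter) shows. Replacing the cyclohexyl ring of compound 1 with an open chain mattered more, giving a 9.3-fold lower number from compound 1 to compound 2 (0.97 log units; beyond the scatter) and a 7.6-fold lower number from compound 1 to compound 3 (0.88 log units; beyond the scatter). Going by the values given here, compound 4 also carries a ring, but a three-membered one, and no measured compound shows how such a ring behaves. A large loss like the gap to compound 1 therefore seems unlikely, though a slight drift towards higher numbers is reasonable. The expected result is a 1.4-fold higher number from compound 3 to compound 4 (0.13 log units; within the scatter), with no clear step beyond the scatter. In this assay, the estimate for compound 4 is 450 nM, with an expected range from 150 nM to 1500 nM.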

Compound 4, concentration for 50% growth inhibition: 250 nM
Compound 4: middle estimate off by 1.8-fold (0.26 log units), on the high side, and the stated range covers the measured number.
By their numbers in this assay, from the lowest: compounds 4, 2 and 3 (each within the scatter of the next); then compound 1.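

At this position, on a saturated chain carbon bound to an oxygen on an unsaturated carbon and a triple-bonded carbon, carrying a ring does not by itself weaken growth inhibition in this assay: cyclopropyl sits level with the open chains, with a 1.3-fold lower number from compound 3 to compound 4 (0.12 log units; within the scatter) and a 1.1-fold lower number from compound 2 to compound 4 (0.03 log units; within the scatter). Until now the only ring in the set was the cyclohexyl of compound 1, so a ring and the higher number could not be told apart, but the cyclopropyl ring gives a 10-fold lower number from compound 1 to compound 4 (1.00 log units; beyond the scatter), a step much like those from compound 1 to the open-chain compounds, and among these four compounds the higher number belongs to cyclohexyl alone. Nothing measured here explains why cyclohexyl stands apart from cyclopropyl, propyl and isobutyl.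

The compounds shown leave open where between cyclopropyl and cyclohexyl the change sets in, which cyclobutyl or cyclopentyl at this position could show. They also leave open how a longer chain such as hexyl, a flat phenyl ring or a chain ending in an amine would behave here.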